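The compounds below may be only part of what the source reports. "The series", "measured", "known", "first", "only" and "open" are said of these compounds alone.

Measured compounds:
- compound 1 `Fc1ccc(Nc2ccnc(NCCNc3ccnc4cc(Cl)ccc34)n2)cc1`: "not active" (no number reported) in an ADME assay on Vero cells (Chlorocebus sabaeus) for cytotoxicity, read by neutral red uptake, with a stated time of 72 h; on this read-out higher numbers stand for weaker inhibition and lower numbers for stronger inhibition
- compound 2 `Clc1ccc2c(NCCNc3nccc(Nc4ccc(Br)cc4)n3)ccnc2c1`: "not active" (no number reported) in this assay
- compound 3 `Cc1ccc(Nc2ccnc(NCCNc3ccnc4cc(Cl)ccc34)n2)cc1`: 13600 nM in this assay

Going by the values given here, compound 3 is the only member of the series with a number in this assay; compound 1 and compound 2 return no number at all, so there is nothing to rank compound 3 against and no step between measured compounds can be drawn. The one-place change to compound 4 `COc1cc(Nc2ccnc(NCCNc3ccnc4cc(Cl)ccc34)n2)cc(OC)c1` is 3,5-dimethoxyphenyl in place of 4-methylphenyl on a nitrogen on an aromatic ring. Among the compounds with values here, no measured pair shows what a change of this kind does in this assay, so the expectation rests on compound 3 alone. Given that two close analogues give no number, the step is expected to be small or to lean toward weaker inhibition rather than stronger, with a real chance that compound 4 also yields no number. The expected step from compound 3 to compound 4 is a 1.5-fold higher number from compound 3 to compound 4 (0.17 log units; within the scatter). For compound 4 the estimate in this assay is 20000 nM, with a range from 7000 nM to 60000 nM.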

Compound 4, half-maximal inhibitory concentration: "not active" (no number reported)
Compound 4: no number reported, so the estimate cannot be set against anything.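

Going by these compounds alone, compound 4 gives "not active" (no number reported) in this assay and so no step from compound 3 to compound 4 can be read. The compounds shown leave open how far this assay responds to 3,5-dimethoxyphenyl in place of 4-methylphenyl. No available evidence bears on this result.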